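Isobutyl in place of sec-butyl

The compounds below may be only part of what the source reports. "The series", "measured", "known", "first", "only" and "open" are said of these compounds alone.

In a functional assay on HeLa cells (Homo sapiens) for cytotoxicity, read by MTT assay, with a stated time of 48 h (on this read-out higher numbers stand for weaker inhibition and lower numbers for stronger inhibition), compound 1 `COC(=O)[C@@H](NC(=O)CSC1=C(C)C(=O)c2ccccc2C1=O)C(C)C` gives 20000 nM as its reading. Compound 2 `CC[C@H](C)[C@H](NC(=O)CSC1=C(OC)C(=O)c2ccccc2C1=O)C(=O)OC` gives 82000 nM and holds the higher of the two numbers, a gap beyond the usual scatter. Not yet measured, compound 3 `COC(=O)[C@H](CC(C)C)NC(=O)CSC1=C(OC)C(=O)c2ccccc2C1=O` has the same atoms as compound 2, joined differently: isobutyl in place of sec-butyl on a saturated chain carbon bound to an amide-type nitrogen and a carbonyl carbon with isobutyl in place of sec-butyl on a saturated chain carbon bound to an amide-type nitrogen and a carbonyl carbon. Going by the values given here, no measured pair shows this change, so the expected move is none beyond the scatter, an estimated 1.4-fold lower number from compound 2 to compound 3 (0.14 log units; within the scatter) in all. For compound 3 the estimate is 60000 nM with an expected range from 25000 nM to 130000 nM at this stage.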

Compound 3, half-maximal inhibitory concentration: 63000 nM
For compound 3 the middle estimate is 1.1-fold (0.02 log units) below the measured one; the measured number falls inside the stated range.
By their numbers in this assay, from the lowest: compound 1; then compounds 3 and 2 (each within the scatter of the next).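

Isobutyl in place of sec-butyl on a saturated chain carbon bound to an amide-type nitrogen and a carbonyl carbon gives a 1.3-fold lower number from compound 2 to compound 3 (0.11 log units; within the scatter) in this assay. This is the first pair shown that differs in one place, and here these two four-carbon groups cannot be told apart. No further measurement bears on this result. On these data alone, what remains open is how the reading would respond to a clearly different group on that carbon, such as a longer chain or a chain carrying an amine or a carboxylic acid.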